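This account rests on a few compounds, and the source may have more. Where it says the series, first, only, none or still open, it means among the compounds named here.

Compound 3, `CCCCCCCCCCCCCCNC(=O)[C@@H](NC(=O)c1ccccc1)[C@@H](C)O`, carries a benzoyl group on the amine nitrogen of the core it shares with compound 1, `CCCCCCCCCCCCCCNC(=O)[C@@H](N)[C@@H](C)O`. In a functional assay on SiHa cells (Homo sapiens) for cytotoxicity, read by MTT assay, with a stated time of 48 h (on this read-out higher numbers stand for weaker inhibition and lower numbers for stronger inhibition), compound 1 gives 11000 nM. For compound 3 this assay reports only a limit, > 200000 nM. The step of an at least 18-fold higher number from compound 1 to compound 3 (1.25 log units; beyond the scatter) is therefore a large move toward weaker inhibition, and compound 3 sits at the limit of > 200000 nM in this assay, at which 1 of the 3 values shown sits, so where it truly stands beyond that bound is not known. Compound 2, `CCCCCCCCCCCCNC(=O)[C@@H](NC(=O)c1ccco1)[C@@H](C)O`, bears the (furan-2-yl)carbonyl group on the same nitrogen but on a different alkyl chain; in this assay compound 2 gives 64300 nM, a number rather than a limit.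

Compound 4, `CCCCCCCCCCCCCCNC(=O)[C@@H](NC(=O)c1ccco1)[C@@H](C)O`, differs from compound 3 by furan-2-yl in place of phenyl on a carbonyl carbon. Going by the values given here, only one measured step touches this position, an at least 18-fold higher number from compound 1 to compound 3 (1.25 log units; beyond the scatter), and it covers the whole acyl group rather than the exchange of one ring for another, so it sets the scale of what the benzoyl costs but not what the furan returns. Compound 2 shows that the furan-bearing acyl group can give a measurable number. Compound 4 is accordingly expected to show a step of an at least 1.6-fold lower number from compound 3 to compound 4 (0.22 log units; that floor lies within the scatter) in this assay. For compound 4 the estimate is 120000 nM, with an expected range from 45000 nM to 300000 nM.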

Compound 4, half-maximal inhibitory concentration: 127000 nM
Compound 4: middle estimate off by 1.1-fold (0.02 log units), on the low side; low and high end bracket the measured number.
By their numbers in this assay, from the lowest: compound 1; then compounds 2 and 4 (each within the scatter of the next). At a limit, above all of these: compound 3.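

In this assay, the large cost of acylating the amine nitrogen is now measured as a number rather than a limit, with the chain of compound 1 kept and (furan-2-yl)carbonyl in place of hydrogen: the step is a 12-fold higher number from compound 1 to compound 4 (1.06 log units; beyond the scatter). Exchanging the ring on the carbonyl carbon gives an at least 1.5-fold lower number from compound 3 to compound 4 (0.19 log units; that floor lies within the scatter), so furan-2-yl in place of phenyl is not shown to return anything beyond the scatter. The change in the alkyl chain gives a 2.0-fold higher number from compound 2 to compound 4 (0.30 log units; within the scatter), so with this acyl group the two chain lengths of compound 2 and compound 4 cannot be told apart in this read-out.

Going by these compounds, how far the ring exchange truly reaches stays open, since compound 3 stands only at a limit: the limit of > 200000 nM in this assay, at which 1 of the 4 values shown sits. Also open, on these data alone, is whether a smaller acyl group such as acetyl, or an amine or a carboxylic acid on the furan ring, would bring the number back toward that of compound 1, and whether a much shorter chain would leave it where it is.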